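The source may hold more compounds than are shown below. What is called first, only, known or untested is meant among the compounds shown, and "the series" means these compounds.

Compound 1 `CCC1(Cc2ccccc2)OS(=O)(=O)C=C1OCc1ccccc1` — >= 50000 nM
Compound 2 `CCC1(Cc2ccccc2)OS(=O)(=O)C=C1OCc1cccc(Cl)c1` — >= 20000 nM
Compound 3 `CCC1(Cc2ccccc2)OS(=O)(=O)C=C1OCc1ccc(Br)cc1` — 80000 nM

All three were measured in an ADME assay on HEL cells (Homo sapiens) for cytotoxicity, with a stated time of 3 days; a lower number here means that less compound is tolerated, a higher number that more compound is tolerated. Compound 1 stands at a limit of the assay rather than a number, >= 50000 nM, which is the limit of >= 50000 nM in this assay, at which 1 of the 3 values shown sits. Compound 2 also stands at a limit, >= 20000 nM, which is the limit of >= 20000 nM in this assay, at which 1 of the 3 values shown sits. Compound 3 alone gives a number, 80000 nM. The steps a step that the two limits leave unreadable from compound 1 to compound 2, a step that the limit leaves unreadable from compound 1 to compound 3 and a step that the limit leaves unreadable from compound 2 to compound 3 are therefore all unreadable, and none of them touches the change now considered. Compound 4 `CCC1(Cc2ccccc2)OS(=O)(=O)C=C1OCCc1ccccc1` differs from compound 1 by benzyl in place of phenyl on a saturated chain carbon bound to an oxygen on an unsaturated carbon. Among the measured compounds shown here, no measured step bears on this change, so no movement beyond the scatter is expected in this assay. The step from compound 1 is estimated as a step that the limit leaves unreadable from compound 1 to compound 4. Compound 4 is expected to give about 60000 nM, between 25000 nM and 150000 nM.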

Compound 4, minimum cytotoxic concentration: >= 20000 nM
Compound 4 ended at the assay's limit (the forecaster's own chance of this, stated with the estimate: 55%); the middle value is on the limit's open side.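

In this assay compound 4 stands at a limit, >= 20000 nM, and its steps from compound 1, compound 2 and compound 3 cannot be read. The compounds shown leave open whether benzyl in place of phenyl shifts the tolerated concentration in this assay at all.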